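A few compounds are considered here, and "the series" means these few. Any claim that something is new, unique, unknown or untested is made for them only; others in the source may bear on it.

In a functional assay on KB cells (Homo sapiens) for inhibition (a lower number here means a stronger inhibitor, a higher number a weaker inhibitor), compound 1 `COc1ccc(Cn2c(N)c(C#N)c3c(N)ncnc32)cc1` gives 50000 nM, and compound 2 `CCCn1c(N)c(C#N)c2c(N)ncnc21` gives 15000 nM. Compound 3 `Cc1cccc(Cn2c(N)c(C#N)c3c(N)ncnc32)c1` reads > 100000 nM, which is a limit of the assay and not a number. Its exact standing is therefore unknown. Compound 4 `Cc1ccc(Cn2c(N)c(C#N)c3c(N)ncnc32)cc1` has the same atoms joined differently: 4-methylphenyl in place of 3-methylphenyl on a saturated chain carbon bound to an aromatic nitrogen, with 4-methylphenyl in place of 3-methylphenyl on a saturated chain carbon bound to an aromatic nitrogen.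

For the measured compounds named here, only one measured step bears on this site, an at least 6.6-fold higher number from compound 2 to compound 3 (0.82 log units; beyond the scatter). It is beyond the scatter, but it exchanges ethyl for an aryl group and does not test moving the methyl. Compound 1, with a methoxy-bearing phenyl at the same place, gives 50000 nM, so a measurable value for compound 4 seems plausible. The expected step is an at least 2.0-fold lower number from compound 3 to compound 4 (0.30 log units; that floor lies within the scatter), toward a lower number in this assay, though its size is uncertain. For compound 4, the estimated value is 50000 nM, with an expected range from 20000 nM to 100000 nM.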

Compound 4, half-maximal inhibitory concentration: > 100000 nM
Compound 4 ended at the assay's limit; the forecaster's own chance of this, stated with the estimate: 35%; middle value at least 2.0-fold (0.30 log units) from the limit.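

Replacing ethyl with 4-methylphenyl on a saturated chain carbon bound to an aromatic nitrogen gives an at least 6.6-fold higher number from compound 2 to compound 4 (0.82 log units; beyond the scatter) in this assay, so a weaker reading beyond the scatter now holds for both the 3-methylphenyl and the 4-methylphenyl groups. Methyl in place of methoxy gives an at least 2.0-fold higher number from compound 1 to compound 4 (0.30 log units; that floor lies within the scatter), and that floor does not separate the two groups. The effect of moving the methyl cannot be read, as the step between compound 3 and compound 4 rests on two limits of the assay and not on numbers: the limit of > 100000 nM in this assay, at which 2 of the 4 values shown sit.

As far as these compounds go, the true values of compound 3 and compound 4 stay unknown, so the two methyl placements cannot be ordered. Also open, from the compounds shown here alone, is whether an amine or a carboxylic acid on the phenyl ring, or a butyl chain in place of the aryl group, would give a measurable value here.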